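Replacing Imidazolyl by Dimethylamino on a Chain Carbon

The source may hold more compounds than are shown below. What is called first, only, known or untested is meant among the compounds shown, and "the series" means these compounds.

Compound 1, `CC(C#CCn1ccnc1)N1CCCC1=O`: > 100 mg/kg
Compound 2, `CC(C#CCN(C)C)N1CCCC1=O`: 6.6 mg/kg
Compound 3, `CC1CCC(=O)N1CC#CCn1ccnc1`: > 100 mg/kg

Of the compounds shown here, three have been measured in a functional assay on the whole organism for agonist activity, with Mus musculus as the target; a higher number here means that more compound is needed for the effect, a lower number that less compound is needed. For compound 1 the result is only a limit of the assay, > 100 mg/kg. Compound 2 gives 6.6 mg/kg. The change from compound 1 to compound 2 is dimethylamino in place of 1H-imidazol-1-yl on a saturated chain carbon bound to a triple-bonded carbon and it made a step of an at least 15-fold lower number from compound 1 to compound 2 (1.18 log units; beyond the scatter). For compound 3 the result is again only a limit of the assay, > 100 mg/kg. The difference between the core of compound 3 and the core of compound 1 is not broken down here. Compound 4, `CC1CCC(=O)N1CC#CCN(C)C`, has not been measured; it differs from compound 3 by dimethylamino in place of 1H-imidazol-1-yl on a saturated chain carbon bound to a triple-bonded carbon, the same change as from compound 1 to compound 2. Two of the three values sit at the limit (the limit of > 100 mg/kg in this assay, at which 2 of the 3 values shown sit), so the size of the coming step is open. Compound 4 is expected to give 12 mg/kg, between 3 mg/kg and 60 mg/kg, because the same change gave an at least 15-fold lower number from compound 1 to compound 2 (1.18 log units; beyond the scatter). This estimate means an expected step of an at least 8.3-fold lower number from compound 3 to compound 4 (0.92 log units; beyond the scatter).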

Compound 4, dose for half-maximal effect: 3 mg/kg
For compound 4 the middle estimate is 4.0-fold (0.60 log units) above the measured one; low and high end bracket the measured number.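

In this assay, dimethylamino in place of 1H-imidazol-1-yl also lowers the number on the second core, with an at least 33-fold lower number from compound 3 to compound 4 (1.52 log units; beyond the scatter). The change therefore carries over in direction and is large on both cores: the same change on two cores in this assay, an at least 15-fold lower number (1.18 log units; beyond the scatter) from compound 1 to compound 2 and an at least 33-fold lower number (1.52 log units; beyond the scatter) from compound 3 to compound 4; the limit leaves it open whether they differ. Both steps start from a limit of the assay, so neither gives a true size, and two cores show nothing about any other core: the limit of > 100 mg/kg in this assay, at which 2 of the 4 values shown sit.

The compounds shown leave open whether another amine, such as diethylamino or pyrrolidin-1-yl, would do the same as dimethylamino. They also leave open whether a longer chain carrying the dimethylamino group would keep the number as low in this assay.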